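This account rests on a few compounds, and the source may have more. Where it says the series, first, only, none or still open, it means among the compounds named here.

In an assay on Cerebral cortex for binding affinity to adenosine receptor A1 (Cavia porcellus), read by radioligand binding (on this read-out higher numbers stand for weaker inhibition and lower numbers for stronger inhibition), compound 1, `C=CCCn1cnc2c1c(=O)n(C)c(=O)n2CCC`, gives 6000 nM, and compound 3, `CCCn1c(=O)n(C)c(=O)c2c1ncn2CCOCC`, gives 24300 nM, the highest of the two plain numbers measured here. Compound 2, `CCCn1c(=O)n(C)c(=O)c2c1ncn2CCCN(C)C`, gives only a limit of the assay, > 200000 nM; this is the limit of the limit of > 200000 nM in this assay, at which 1 of the 3 values shown sits. The step of a 4.1-fold higher number from compound 1 to compound 3 (0.61 log units; beyond the scatter) is modest, the step of an at least 33-fold higher number from compound 1 to compound 2 (1.52 log units; beyond the scatter) is large, and the step of an at least 8.2-fold lower number from compound 2 to compound 3 (0.91 log units; beyond the scatter) is at least modest.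

Compound 4, `CCCn1c(=O)n(C)c(=O)c2c1ncn2CCC(C)=O`, differs from compound 3 by a single change: acetyl in place of ethoxy on a saturated chain carbon, two bonds along the chain from an aromatic nitrogen. Both the ethoxy that leaves and the acetyl that enters carry one hydrogen-bond acceptor and no charge. Of the measured steps, the exchange of a vinyl for a dimethylaminomethyl group at this same place raised the number sharply, while the exchange for an ethoxy group raised it only modestly; none of them swaps one neutral oxygen-bearing group for another. For compound 4 a step of a 1.2-fold higher number from compound 3 to compound 4 (0.09 log units; within the scatter) is therefore expected, which is within the usual scatter. Compound 4 is estimated at 30000 nM in this assay, with a plausible range from 8000 nM to 120000 nM.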

Compound 4, inhibition constant: 30000 nM
Estimate against measurement, compound 4: no gap at the digits printed; the measured number falls inside the stated range.
By their numbers in this assay, from the lowest: compound 1; then compounds 3 and 4 (each within the scatter of the next). At a limit, above all of these: compound 2.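

In this assay, acetyl in place of ethoxy gives a 1.2-fold higher number from compound 3 to compound 4 (0.09 log units; within the scatter), so at this place on the chain two different uncharged groups, each with one oxygen and the same heavy-atom count, cannot be told apart. The acetyl group still reads apart from the other two groups, with a 5.0-fold higher number from compound 1 to compound 4 (0.70 log units; beyond the scatter) on the vinyl side and an at least 6.6-fold lower number from compound 2 to compound 4 (0.82 log units; beyond the scatter) on the (dimethylamino)methyl side. That second step is open-ended, since compound 2 gives only a limit and not a number: the limit of > 200000 nM in this assay, at which 1 of the 4 values shown sits.

Going by these compounds, whether any group at this place could give a lower number than the vinyl of compound 1 remains open. A hydroxyl, a carboxylic acid or a longer carbon chain might show whether the oxygen matters at all, or only the chain around it.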